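The source may hold more compounds than are shown below. What is called first, only, known or untested is meant among the compounds shown, and "the series" means these compounds.

In a functional assay on the whole organism (Cricetulus griseus) with Cricetinae gen. sp. as the target (a lower number here means that less compound is needed, a higher number that more compound is needed for the effect), compound 1 `COc1cccc(-c2n[nH]c(-c3ccccc3C=O)n2)c1` gives 0.1 mg/kg, compound 2 `Cc1ccc(-c2n[nH]c(-c3ccccc3)n2)c(C)c1` gives 0.2 mg/kg, and compound 3 `Cc1ccc(Cl)cc1-c1n[nH]c(-c2ccccc2)n1` gives 1.2 mg/kg. Compound 3 thus stands highest of the three: compound 2 sits well below it and compound 1 further still, both gaps beyond the usual scatter. Compound 4 `COc1ccc(C)c(-c2n[nH]c(-c3ccccc3)n2)c1` differs from compound 3 by one exchange: methoxy in place of chloro on an aromatic carbon. For the measured compounds named here, no measured pair isolates this exchange, so its size is unknown. Compound 1, which also carries a methoxy group and gives 0.1 mg/kg, is the only hint that a methoxy can sit on a compound with a low number. A modest downward step is therefore expected, as in a 3.0-fold lower number from compound 3 to compound 4 (0.48 log units; beyond the scatter). For compound 4 the estimate is 0.4 mg/kg, ranging from 0.1 mg/kg to 1.5 mg/kg.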

Compound 4, dose for half-maximal effect: > 10 mg/kg
Compound 4 ended at the assay's limit (the forecaster's own chance of this, stated with the estimate: 5%); at least 25-fold (1.39 log units) between middle value and limit.
By their numbers in this assay, from the lowest: compounds 1 and 2 (each within the scatter of the next); then compound 3. At a limit, above all of these: compound 4.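

Methoxy in place of chloro, on the aromatic carbon para to a methyl group, makes a large difference in this assay: the exchange brings an at least 8.3-fold higher number from compound 3 to compound 4 (0.92 log units; beyond the scatter). This single change is enough to carry the compound beyond the scatter, so this position is sensitive to which group sits there. The value of compound 4 is a limit and not a number: the limit of > 10 mg/kg in this assay, at which 1 of the 4 values shown sits.

The compounds shown leave open what a hydroxy group or an amine would do at this place. They also give no reason why chloro and methoxy lie so far apart.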